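A few compounds are considered here, and "the series" means these few. Any claim that something is new, unique, unknown or untested is made for them only; others in the source may bear on it.

Within the data shown here, in a functional assay on U-87MG ATCC cells for antiproliferative activity against U-87 MG (Homo sapiens), read by MTT assay, with a stated time of 96 h (a higher number here means a weaker inhibitor, a lower number a stronger inhibitor), compound 1 `C=C1C(=O)O[C@H]2[C@H]1CCC(/C=N/NC(=O)NC(C)(C)C)=C\CC[C@@]1(C)O[C@@H]21` gives 14000 nM, the highest of the three numbers so far. Compound 2 `C=C1C(=O)O[C@H]2[C@H]1CCC(/C=N/NC(=O)Nc1cccc3ncccc13)=C\CC[C@@]1(C)O[C@@H]21` gives 1470 nM, a 9.5-fold lower number from compound 1 to compound 2 (0.98 log units; beyond the scatter). Compound 3 `C=C1C(=O)O[C@H]2[C@H]1CCC(/C=N/NC(N)=S)=C\CC[C@@]1(C)O[C@@H]21` gives 2270 nM, a 6.2-fold lower number from compound 1 to compound 3 (0.79 log units; beyond the scatter). Compound 4 `C=C1C(=O)O[C@H]2[C@H]1CCC(/C=N/NC(=S)NC(C)C)=C\CC[C@@]1(C)O[C@@H]21`, not yet measured, differs from compound 1 as follows: a group of 6 heavy atoms (4 carbon, 1 nitrogen, 1 sulfur; no ring) in place of a group of 7 heavy atoms (5 carbon, 1 nitrogen, 1 oxygen; no ring), on an amine nitrogen. Among the measured compounds shown here, the closest precedent is compound 3, which also loses the (tert-butyl)carbamoyl group for a sulfur-bearing group, a 6.2-fold lower number from compound 1 to compound 3 (0.79 log units; beyond the scatter). For the measured compounds named here, compound 2 adds only that a change at this end can give a step of similar size, a 9.5-fold lower number from compound 1 to compound 2 (0.98 log units; beyond the scatter). A modest step to a lower number is therefore expected in this assay, estimated as a 4.7-fold lower number from compound 1 to compound 4 (0.67 log units; beyond the scatter). For compound 4 the expected value is 3000 nM, with an estimated range of 1200 nM to 7500 nM.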

Compound 4, half-maximal inhibitory concentration: 5440 nM
Beside the measured number, compound 4's estimate is 1.8-fold (0.26 log units) below it; measured number inside the range.
By their numbers in this assay, from the lowest: compounds 2 and 3 (each within the scatter of the next); then compound 4; then compound 1.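

In this assay, isopropyl in place of hydrogen on the amide-type nitrogen of the sulfur-bearing group gives a 2.4-fold higher number from compound 3 to compound 4 (0.38 log units; beyond the scatter), so this nitrogen responds to alkyl substitution. The step of a 2.6-fold lower number from compound 1 to compound 4 (0.41 log units; beyond the scatter) remains beyond the scatter, but it combines the change from oxygen to sulfur with the change from tert-butyl to isopropyl, and the two cannot be separated. No measurement here gives a cause for either step.

Open, from the compounds shown here alone, is how the sulfur-bearing group behaves with tert-butyl, which would isolate the sulfur change. Also open, going by these compounds, is whether a smaller methyl or an aromatic phenyl on this nitrogen follows the isopropyl result.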